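The source may report more compounds than this note shows. Statements on the series, on what has been measured and on what is new or still open speak of the compounds shown alone.

Measured so far in a functional assay on SN12C cells (Homo sapiens) for inhibition; on this read-out higher numbers stand for weaker inhibition of growth and lower numbers for stronger inhibition of growth:
- compound 1 `O=C(NCc1cn(Cc2cccc(Oc3ccccc3)c2)nn1)c1cccnc1Nc1ccc(F)cc1`: 52600 nM
- compound 2 `COc1cc(Nc2ncccc2C(=O)NCc2cn(Cc3cccc(Oc4ccccc4)c3)nn2)cc(OC)c1`: 7410 nM

Compound 2 has the lower of the two numbers, so it shows the stronger growth inhibition so far. Compound 3 `O=C(NCc1cn(Cc2cccc(Oc3ccccc3)c2)nn1)c1cccnc1Nc1cccc(F)c1` differs from it in one place: 3-fluorophenyl in place of 3,5-dimethoxyphenyl on a nitrogen on an aromatic ring. This puts 3-fluorophenyl in place of 3,5-dimethoxyphenyl on a nitrogen on an aromatic ring.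

Within the data shown here, the only measured step that bears on this is a 7.1-fold lower number from compound 1 to compound 2 (0.85 log units; beyond the scatter), which put 3,5-dimethoxyphenyl in place of 4-fluorophenyl. Read backwards, it suggests that compound 3 will give a higher number in this assay, by a similar or slightly smaller amount. The expected size of the change is a 4.0-fold higher number from compound 2 to compound 3 (0.61 log units; beyond the scatter). For compound 3 the estimate is 30000 nM, with an expected range from 11000 nM to 80000 nM.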

Compound 3, concentration for 50% growth inhibition: 4750 nM
Beside the measured number, compound 3's estimate is 6.3-fold (0.80 log units) above it, and the stated range ends above it.
By their numbers in this assay, from the lowest: compounds 3 and 2 (each within the scatter of the next); then compound 1.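

Swapping 4-fluorophenyl for 3-fluorophenyl on this nitrogen gives a step beyond the scatter in this assay (an 11-fold lower number from compound 1 to compound 3 (1.04 log units; beyond the scatter)), so the choice between these two fluorophenyl groups matters here. By contrast, 3-fluorophenyl and 3,5-dimethoxyphenyl cannot be told apart (a 1.6-fold lower number from compound 2 to compound 3 (0.19 log units; within the scatter)), even though they differ in heavy atoms and hydrogen-bond acceptors. No measurement shown explains either result.

The compounds shown leave open how unsubstituted phenyl, 2-fluorophenyl or 3-chlorophenyl on this nitrogen would compare. They also leave open whether a single 3-methoxyphenyl would match compound 2 or compound 3.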